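Second chloro on the core of compound 2

The source may hold more compounds than are shown below. What is called first, only, known or untested is meant among the compounds shown, and "the series" means these compounds.

Measured compounds:
compound 1 `ClCc1ccccc1Cn1cnc2c(Cl)ncnc21`: 38900 nM
compound 2 `ClCc1cccc(Cn2cnc3c(Cl)ncnc32)c1`: 8910 nM
compound 3 `ClCc1ccc(Cn2cnc3nc(Cl)nc(Cl)c32)cc1`: 15500 nM

All three numbers come from a functional assay on NCI-H226 cells (Homo sapiens) for cytotoxicity, read by sulforhodamine B assay, with a stated time of 48 h; a higher number here means that more compound is tolerated, a lower number that less compound is tolerated. Compound 2 stands lowest of the three; its number and that of compound 3 lie within the scatter of each other, while compound 1 stands beyond the scatter above compound 2. No two of these compounds differ in only one place, so no single step among them can be read off.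

Compound 4 `ClCc1cccc(Cn2cnc3c(Cl)nc(Cl)nc32)c1` has not yet been measured. It differs from compound 2 by chloro in place of hydrogen on an aromatic carbon — chloro in place of hydrogen on an aromatic carbon. Going by the values given here, no measured pair isolates this change. The closest hint is compound 3, whose core also bears a chloro group between two ring nitrogen atoms and which, with a different substitution of the benzyl ring, gives a number within the scatter of compound 2. On that basis the step expected in this assay from compound 2 to compound 4 is no size beyond the scatter, a 1.3-fold higher number from compound 2 to compound 4 (0.13 log units; within the scatter). Compound 4 is therefore estimated at 12000 nM, with a range from 5000 nM to 30000 nM.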

Compound 4, concentration lethal to 50% of the cells: 40700 nM
For compound 4 the middle estimate is 3.4-fold (0.53 log units) below the measured one; measured number above the stated range.
By their numbers in this assay, from the lowest: compounds 2 and 3 (each within the scatter of the next); then compounds 1 and 4 (each within the scatter of the next).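

In this assay, going by these compounds alone, chloro in place of hydrogen on an aromatic carbon, between two ring nitrogen atoms, gives a 4.6-fold higher number from compound 2 to compound 4 (0.66 log units; beyond the scatter), the first step that can be read at a single place, and it lies beyond the scatter. This position is therefore not indifferent to the change: with the rest of compound 2 unchanged, the chloro group raises the number, so that more compound is tolerated in this assay. Nothing available bears on why the number moves in this direction.

Going by these compounds, a single pair speaks for this position, so it remains open whether the rise is specific to chloro or would also appear with another group in place of that hydrogen, such as an amine or a methoxy group. On these data alone, it is also open whether the step carries over to other substitutions of the benzyl ring: compound 1 and compound 3 each differ from compound 4 in more than one place, and their steps to it cannot be read.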